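Thioether chain length on the shared core

The source may hold more compounds than are shown below. What is called first, only, known or untested is meant among the compounds shown, and "the series" means these compounds.

Compound 1 `CCCSCC1C2CCC(O2)C1C/C=C\CCCC(=O)O` and compound 2 `C=CCSCC1C2CCC(O2)C1C/C=C\CCCC(=O)O` differ only at the saturated chain carbon bound to a sulfur. In an assay (Cavia porcellus) for inhibition of thromboxane A2 receptor (Homo sapiens) (a higher number here means weaker binding, a lower number tighter binding), compound 1 gives 97 nM, and in this assay compound 2 gives 76 nM. Going by the values given here, the step of a 1.3-fold lower number from compound 1 to compound 2 (0.11 log units; within the scatter) is the only measured step in the set, and the two numbers lie within the scatter of each other, so no order can be read between compound 1 and compound 2.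

Compound 3 `C=CCCSCC1C2CCC(O2)C1C/C=C\CCCC(=O)O` carries the change (allyl in place of vinyl on a saturated chain carbon bound to a sulfur). This is one further lengthening of the chain on the sulfur by a single carbon, of the same kind as the change from compound 1 to compound 2, which bears directly on it: that step a 1.3-fold lower number from compound 1 to compound 2 (0.11 log units; within the scatter) stayed within the scatter. For compound 3 the expected step of a 1.0-fold lower number from compound 2 to compound 3 (0.01 log units; within the scatter) is therefore also one not beyond the scatter, with no clear direction. The estimate for compound 3 in this assay is 75 nM, with a range from 35 nM to 160 nM.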

Compound 3, dissociation constant: 49 nM
Compound 3: the middle estimate sits 1.5-fold (0.18 log units) above what was measured; low and high end bracket the measured number.
By their numbers in this assay, from the lowest: compounds 3, 2 and 1 (each within the scatter of the next).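

In this assay, the further single-carbon lengthening on the sulfur gives a 1.6-fold lower number from compound 2 to compound 3 (0.19 log units; within the scatter), so a second change of this kind at the position also stays within the scatter, and compound 3 cannot be placed in any order relative to compound 2. The comparison across both changes gives a 2.0-fold lower number from compound 1 to compound 3 (0.30 log units; within the scatter) and is also printed as within the scatter, so compounds 1, 2 and 3 form one group at this position, with no trend in chain length that can be read from them. No supporting data on the series bear on why these three numbers stay so close together.

The compounds shown leave open whether any replacement for the but-3-en-1-yl group on the sulfur would move the number beyond the scatter, for example a longer chain, the fully saturated butyl chain or a phenyl ring. They also leave open whether an amine or a carboxylic acid at the end of that chain would be accepted at this position in the same way as the three thioether chains seen so far.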